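A Hydroxy Swap on a Weakly Cytotoxic Pair

This account rests on a few compounds, and the source may have more. Where it says the series, first, only, none or still open, it means among the compounds named here.

compound 1 `CCC(CO)Nc1nc(NCc2cccc(O)c2)c2nc(Cl)n(C(C)C)c2n1` gives 27000 nM
compound 2 `CCC(CO)Nc1nc(NCc2ccccc2)c2nc(Br)n(C(C)C)c2n1` gives 53000 nM

In a functional assay on MCF7 cells (Homo sapiens) for cytotoxicity (a higher number here means a weaker inhibitor, a lower number a stronger inhibitor), compound 2 reads (53000 nM) and sits within the usual scatter of compound 1 (27000 nM), so the two numbers cannot be told apart. Among the compounds with values here, these two compounds also differ in more than one place, so they offer no clean step. Compound 3 (`CCC(CO)Nc1nc(NCc2ccccc2)c2nc(O)n(C(C)C)c2n1`) keeps the rest of compound 2 but carries hydroxy in place of bromo on an aromatic carbon. Neither measured compound carries hydroxy at this place, so the expectation is loose. A modest move toward a higher number is expected in this assay, though it may not pass the scatter. The expected change is a 1.2-fold higher number from compound 2 to compound 3 (0.09 log units; within the scatter) and remains an estimate. Compound 3 is estimated at 65000 nM (expected range 25000 nM to 170000 nM).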

Compound 3, half-maximal inhibitory concentration: 65000 nM
Compound 3: the middle estimate sits on the measured number at the digits printed; the range from low to high includes it.
By their numbers in this assay, from the lowest: compounds 1, 2 and 3 (each within the scatter of the next, the first and the last beyond it).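

In this assay, within the data shown here, the exchange of bromo for hydroxy gives a 1.2-fold higher number from compound 2 to compound 3 (0.09 log units; within the scatter), the first step in the set that isolates a single place. On this aromatic carbon between two ring nitrogen atoms, the two groups cannot be told apart, even though hydroxy brings a hydrogen-bond donor and acceptor that bromo lacks. So the step shows no sensitivity to this particular exchange, though it says nothing about other groups at this place. Nothing measured here offers an explanation for this outcome.

As far as these compounds go, whether an amine or a methyl group on this carbon would also stay within the scatter of compound 2 remains open. From the compounds shown here alone, it is also open whether hydroxy would read the same in place of the chloro of compound 1, whose other ring carries its own hydroxy.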